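The compounds below may be only part of what the source reports. "The series", "measured", "known", "first", "only" and "open" are said of these compounds alone.

Measured so far:
- compound 1, `COc1cc(/C=C/C(=O)/C=C(O)/C=C/c2ccc(O[C@H]3C=C(C)[C@@H](O)C[C@@H]3[C@@H](C)CC(=O)C=C(C)C)c(OC)c2)ccc1O`, in a functional assay on A549 cells (Homo sapiens) for cytotoxicity, read by crystal violet staining, with a stated time of 72 h; a lower number here means a stronger inhibitor, a higher number a weaker inhibitor: 16100 nM
- compound 2, `COc1cc(/C=C/C(O)=C/C(=O)/C=C/c2ccc(O)cc2)ccc1O[C@H]1C=C(C)[C@@H](O)C[C@@H]1[C@@H](C)CC(=O)C=C(C)C`, in this assay: 16600 nM

Compound 2 stands at the highest of the two numbers shown, but the only step between them, a 1.0-fold higher number from compound 1 to compound 2 (0.01 log units; within the scatter), lies within the scatter, so the two numbers cannot be told apart. Compound 3, `CC(C)=CC(=O)C[C@H](C)[C@H]1C[C@H](O)C(C)=C[C@@H]1Oc1ccc(/C=C/C(O)=C/C(=O)/C=C/c2ccc(O)cc2)cc1`, is not yet measured in this assay. It differs from compound 2 by hydrogen in place of methoxy on an aromatic carbon. Within the data shown here, the one measured step that bears on this change is the same kind of replacement, hydrogen in place of methoxy on an aromatic carbon, and it gave a 1.0-fold higher number from compound 1 to compound 2 (0.01 log units; within the scatter), within the scatter. On that basis no step beyond the scatter is expected in this assay from compound 2 to compound 3; the expected step is a 1.0-fold lower number from compound 2 to compound 3 (0.00 log units; within the scatter). Compound 3 is therefore estimated at 16500 nM in this assay, with a range of 8000 nM to 34000 nM.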

Compound 3, half-maximal inhibitory concentration: 27400 nM
Compound 3: the middle estimate sits 1.7-fold (0.22 log units) below what was measured; the range from low to high includes it.
By their numbers in this assay, from the lowest: compounds 1, 2 and 3 (each within the scatter of the next).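

In this assay, hydrogen in place of methoxy on the aromatic carbon ortho to a large group and meta to a large group gives a 1.7-fold higher number from compound 2 to compound 3 (0.22 log units; within the scatter), so this position, like the one changed earlier, shows no effect that can be read. Compound 3 carries no methoxy on either aromatic ring, and the series reaches that state with each single step inside the scatter. No supporting data bear on this result.

Only methoxy and hydrogen are shown at this position, so it remains open whether an ethoxy, a chlorine or an amine there would give a step beyond the scatter. The compounds shown also leave open whether changes elsewhere in the shared core, such as a carboxylic acid in place of the free phenol hydroxyl, would move the number in this assay.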